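This account rests on a few compounds, and the source may have more. Where it says the series, first, only, none or still open, it means among the compounds named here.

Working notes on the series, all read in an ADME assay on microsomes (Rattus norvegicus) for metabolic stability; a lower number here means that the compound disappears faster, a higher number that the compound lasts longer. Compound 1 (`Cc1ccc(C2CC=NN2C(=O)C(C)(C)C)cc1`) gives 0.0383 h, compound 2 (`O=C(C1CCCC1)N1N=CCC1c1ccccc1`) gives 0.2 h, and compound 3 (`CCC(=O)N1CCC(C(=O)N2N=CCC2c2ccccc2)CC1`) gives 1.07 h. Compound 3 therefore holds the highest number of the three, beyond the scatter from both of the others. Among the measured compounds shown here, no two measured compounds differ in one place only, so the set offers no direct reading of any single change.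

The next compound is compound 4 (`O=C(c1cocn1)N1CCC(C(=O)N2N=CCC2c2ccccc2)CC1`), which differs from compound 3 as follows: 1,3-oxazol-4-yl in place of ethyl on a carbonyl carbon. In words, 1,3-oxazol-4-yl stands in place of ethyl on a carbonyl carbon, so propanoyl becomes (1,3-oxazol-4-yl)carbonyl. For the measured compounds named here, with no measured step to draw on, the expectation starts from compound 3 at 1.07 h, and the direction of any move remains uncertain. The expected change, a 1.2-fold lower number from compound 3 to compound 4 (0.08 log units; within the scatter), is a slight decrease that stays within the scatter. For compound 4 the estimated half-life is 0.9 h, with an expected range of 0.35 h to 2.3 h.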

Compound 4, half-life: 0.533 h
For compound 4 the middle estimate is 1.7-fold (0.23 log units) above the measured one, and the stated range covers the measured number.
By their numbers in this assay, from the lowest: compound 1; then compound 2; then compounds 4 and 3 (each within the scatter of the next).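

In this assay, among the compounds shown here, 1,3-oxazol-4-yl in place of ethyl gives a 2.0-fold lower number from compound 3 to compound 4 (0.30 log units; within the scatter), the first reading of a single change. At this position, on a carbonyl carbon whose other neighbours are an amide-type nitrogen in a ring, a five-membered aromatic ring with 2 hetero atoms can therefore stand in place of ethyl while the half-life remains within the scatter of compound 3. Nothing available bears on what sets the size of this step.

This single step leaves open how other groups would read on the same carbonyl carbon, such as a dimethylamino group, a phenyl ring or a longer chain like butyl. It also leaves open whether the same exchange would read alike with other parts of compound 3 changed.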